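The source may report more compounds than this note shows. Statements on the series, on what has been measured and on what is new or still open speak of the compounds shown alone.

Measured so far:
compound 1 `Nc1ccccc1COc1ccc(OCCOCCNC2CCCC2)cc1`, 14000 nM
compound 2 `COC(=O)c1ccc(COc2ccc(OCCOCCNC3CCCCC3)cc2)cc1`, 6220 nM

In a functional assay on SK-OV-3 cells (Homo sapiens) for inhibition, read by CCK-8 assay, with a stated time of 70 h (a higher number here means a weaker inhibitor, a lower number a stronger inhibitor), compound 1 gives 14000 nM, the highest of the two numbers, so it is the weaker inhibitor of the pair. Compound 2 gives 6220 nM, a lower number that lies beyond the scatter. Compound 3 `O=C(O)c1cccc(COc2ccc(OCCOCCNC3CCCC3)cc2)c1` is not yet measured. It differs from compound 1 in one place: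
3-carboxyphenyl in place of 2-aminophenyl on a saturated chain carbon bound to an oxygen on an aromatic ring
No change between measured compounds matches this one, so the step from compound 1 to compound 3 is expected to be small, a 1.3-fold lower number from compound 1 to compound 3 (0.10 log units; within the scatter), with no clear direction beyond the scatter. Compound 3 is therefore estimated at 11000 nM, between 3500 nM and 35000 nM.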

Compound 3, half-maximal inhibitory concentration: > 100000 nM
Compound 3 gave a limit, no number (the forecaster's own chance of this, stated with the estimate: 10%); at least 9.0-fold (0.95 log units) between middle value and limit.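

In this assay, among these compounds, 3-carboxyphenyl in place of 2-aminophenyl gives an at least 7.1-fold higher number from compound 1 to compound 3 (0.85 log units; beyond the scatter), the first sign that the group on this saturated chain carbon can strongly affect the read-out. Compound 3 gives > 100000 nM, which is a limit and not a number: the limit of > 100000 nM in this assay, at which 1 of the 3 values shown sits.

This single step swaps both the group and where it sits on the ring, and the compounds shown do not separate the two. A plain phenyl group or a primary amide in this place could show how far the loss is specific to the carboxylic acid.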